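A few compounds are considered here, and "the series" means these few. Any claim that something is new, unique, unknown or untested is made for them only; others in the source may bear on it.

Compound 1 `CNC(=O)NC[C@H]1O[C@@H](n2cnc3c(NC(=O)Nc4ccccc4)ncnc32)[C@H](O[Si](C(C)C)(C(C)C)C(C)C)[C@@H]1O[Si](C(C)C)(C(C)C)C(C)C`: in a functional assay on FM3A cells (Mus musculus) for antiproliferative activity, with a stated time of 48 h (a higher number here means a weaker inhibitor, a lower number a stronger inhibitor), compound 1 gives > 200 ug/mL, which is a limit of the assay and not a number.
Compound 2 `CNC(=O)NC[C@H]1O[C@@H](n2cnc3c(NC(=O)Nc4ccccc4)ncnc32)[C@H](OC(=O)c2ccccc2)[C@@H]1OC(=O)c1ccccc1`: in this assay compound 2 gives 61 ug/mL.

Compound 2 therefore holds the only number shown; the one further value is a limit, sitting at the limit of > 200 ug/mL in this assay, at which 1 of the 2 values shown sits. Among the measured compounds shown here, no two measured compounds differ in a single place, so no measured step exists here. Compound 3 `CNC(=O)NC[C@H]1O[C@@H](n2cnc3c(N)ncnc32)[C@H](OC(=O)c2ccccc2)[C@@H]1OC(=O)c1ccccc1` is the compound still to be measured. It differs from compound 2 by hydrogen in place of phenylcarbamoyl on a nitrogen on an aromatic ring; read one bond further out, the change is (phenylcarbamoyl)amino to amino. For the measured compounds named here, with no measured step to lean on, the expectation is a modest weakening in this assay, somewhat beyond the usual scatter but not large, and the estimated step from compound 2 to compound 3 is a 1.8-fold higher number from compound 2 to compound 3 (0.26 log units; within the scatter). Compound 3 is estimated at 110 ug/mL, with a range from 40 ug/mL to 250 ug/mL.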

Compound 3, half-maximal inhibitory concentration: 36 ug/mL
Estimate against measurement, compound 3: 3.1-fold (0.49 log units) above; the whole stated range lies above it.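

Among the compounds shown here, this pair gives the first step in the set that changes one place only: hydrogen in place of phenylcarbamoyl on a nitrogen on an aromatic ring reads a 1.7-fold lower number from compound 2 to compound 3 (0.23 log units; within the scatter) in this assay and so stays inside the usual scatter. For the compounds shown here, the whole phenylcarbamoyl group, with its six-membered aromatic ring, can therefore leave this nitrogen without separating compound 2 from compound 3 in this read-out, which the earlier compounds could not show. Nothing measured here offers a cause for this step.

What the compounds leave open is whether a smaller group on the same nitrogen, such as acetyl or methylcarbamoyl, would read the same way. Also open, from the compounds shown here alone, is whether a phenylcarbamoyl carrying a chlorine or a methoxy group on its ring would stay within the scatter.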